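Swapping Trifluoromethyl for Trifluoromethoxy on a Second Core

This account rests on a few compounds, and the source may have more. Where it says the series, first, only, none or still open, it means among the compounds named here.

Compound 1 `CC(O)(CSc1ccccc1C(F)(F)F)C(=O)Nc1ccc(S(F)(F)(F)(F)F)cc1` and compound 2 `CC(O)(CSc1ccccc1OC(F)(F)F)C(=O)Nc1ccc(S(F)(F)(F)(F)F)cc1` share a core and differ in one place: trifluoromethoxy in place of trifluoromethyl on an aromatic carbon. In a functional assay on CWR22R cells (Homo sapiens) for antiproliferative activity, read by propidium iodide staining, with a stated time of 96 h (on this read-out higher numbers stand for weaker inhibition and lower numbers for stronger inhibition), compound 1 gives 13200 nM, and compound 2 gives 15000 nM, so the step of a 1.1-fold higher number from compound 1 to compound 2 (0.06 log units; within the scatter) is small. Compound 3 `CC(O)(CSc1ccccc1C(F)(F)F)C(=O)Nc1cccc(S(F)(F)(F)(F)F)c1` is built from the same atoms as compound 1, joined differently; the difference between the two cores is not broken down here. In this assay compound 3 gives 13200 nM, level with compound 1. Compound 4 `CC(O)(CSc1ccccc1OC(F)(F)F)C(=O)Nc1cccc(S(F)(F)(F)(F)F)c1` carries the same change on the core of compound 3: trifluoromethoxy in place of trifluoromethyl on an aromatic carbon. The surroundings of the change read the same for both pairs, so this is the same kind of change. Because the step of a 1.1-fold higher number from compound 1 to compound 2 (0.06 log units; within the scatter) stayed within the scatter, the expected step of a 1.1-fold higher number from compound 3 to compound 4 (0.04 log units; within the scatter) is also small. Compound 4 is therefore expected to give about 14500 nM, most likely between 7000 nM and 30000 nM.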

Compound 4, half-maximal inhibitory concentration: 13900 nM
The estimate for compound 4 lay 1.0-fold (0.02 log units) above the measured number; measured number inside the range.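

In this assay, trifluoromethoxy in place of trifluoromethyl again makes little difference on the second core, with a 1.1-fold higher number from compound 3 to compound 4 (0.02 log units; within the scatter). The two steps agree: the same change on two cores in this assay, a 1.1-fold higher number (0.06 log units; within the scatter) from compound 1 to compound 2 and a 1.1-fold higher number (0.02 log units; within the scatter) from compound 3 to compound 4, 1.1-fold (0.03 log units) apart, within the scatter of two such steps. So the change carried over from the core of compound 1 to the core of compound 3 with no shift that can be told from the scatter, but two pairs of closely related compounds cannot show that it would hold on other cores or in other assays, and they do not explain why the step is small.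

The compounds shown leave open whether an amine, a nitrile or a carboxylic acid in place of the trifluoromethyl would move the number beyond the scatter. They also leave open whether a longer chain there would do so.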